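The source may report more compounds than this note shows. Statements on the series, on what has been measured and on what is new or still open speak of the compounds shown alone.

Measured compounds:
Compound 1 `O=C1c2ccccc2C(=O)N1CCCCN1CCN(c2ccc([N+](=O)[O-])cc2)CC1` gives 378 nM in an assay on frontal cortex for binding affinity to Adrenergic receptor alpha-1 (Rattus norvegicus), read by radioligand binding; a higher number here means a weaker inhibitor, a lower number a stronger inhibitor.
Compound 2 `O=C1c2ccccc2C(=O)N1CCCCN1CCN(c2ccccc2[N+](=O)[O-])CC1` gives 25 nM in this assay.

Compound 2 stands at the lowest of the two numbers in this assay; its nearest neighbour is compound 1, separated by a 15-fold lower number from compound 1 to compound 2 (1.18 log units; beyond the scatter). The unmeasured compound 3 `O=C1c2ccccc2C(=O)N1CCCCN1CCN(c2cccc3ccccc23)CC1` differs from compound 2 in a single place: naphthalen-1-yl in place of 2-nitrophenyl on an amine nitrogen in a ring. For the measured compounds named here, the only measured step that bears on this position is a 15-fold lower number from compound 1 to compound 2 (1.18 log units; beyond the scatter), and it shows that changing the group on this ring nitrogen can move the number in this assay by a large amount. That step, however, concerns only a shift of a nitro group; it does not show which way a naphthalen-1-yl group will go. Compound 3 is therefore expected to stay near compound 2, with an estimated step of a 2.1-fold lower number from compound 2 to compound 3 (0.32 log units; beyond the scatter), and an estimated value of 12 nM in this assay, within the range 3 nM to 50 nM.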

Compound 3, inhibition constant: 22 nM
Compound 3: middle estimate off by 1.8-fold (0.26 log units), on the low side, within the range that was stated.
By their numbers in this assay, from the lowest: compounds 3 and 2 (each within the scatter of the next); then compound 1.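

In this assay, the exchange of 2-nitrophenyl for naphthalen-1-yl on the amine nitrogen in the ring gives a 1.1-fold lower number from compound 2 to compound 3 (0.06 log units; within the scatter), so a group with two aromatic rings of carbon only and no hydrogen-bond acceptors can stand here with no difference from compound 2 that rises above the scatter. Measured against 4-nitrophenyl, the same group gives a 17-fold lower number from compound 1 to compound 3 (1.24 log units; beyond the scatter), which shows that a nitro group is not needed at this position for a number well under that of compound 1. Nothing measured here explains this result.

The compounds shown leave open how a plain phenyl, a 2-methoxyphenyl or a naphthalen-2-yl group would read on this nitrogen. They also leave open whether naphthalen-1-yl would hold its number with a shorter chain in the shared core.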